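A few compounds are considered here, and "the series" means these few. Any claim that something is new, unique, unknown or untested is made for them only; others in the source may bear on it.

Measured compounds:
- compound 1 `Clc1ccc(-c2cc(-c3ccccc3)c3cc(Br)ccc3n2)cc1`: 269000 nM
- compound 2 `Brc1ccc2nc(C3CCCCC3)cc(-c3ccccc3)c2c1`: "not determined" (no result reported)
- compound 3 `Brc1ccc2nc(-c3ccco3)cc(-c3ccccc3)c2c1`: 102000 nM

Among the measured compounds shown here, in a functional assay on Hep2C cells (Homo sapiens) for antiproliferative activity, read by MTT assay, with a stated time of 24 h (a higher number here means a weaker inhibitor, a lower number a stronger inhibitor), compound 3 gives the lowest of the two numbers; its nearest neighbour is compound 1, which gives 269000 nM, and the only single step, a 2.6-fold lower number from compound 1 to compound 3 (0.42 log units; beyond the scatter), runs toward compound 3. Compound 4 `Oc1ccc(-c2cc(-c3ccccc3)c3cc(Br)ccc3n2)cc1` carries the change (4-hydroxyphenyl in place of furan-2-yl on an aromatic carbon). For the measured compounds named here, no measured step covers a hydroxyphenyl group; the only related step, a 2.6-fold lower number from compound 1 to compound 3 (0.42 log units; beyond the scatter), shows that a six-membered carbon ring in this place gave a higher number than the furan. On that basis compound 4 is expected to lie between compound 3 and compound 1, with an estimated step of a 1.6-fold higher number from compound 3 to compound 4 (0.20 log units; within the scatter). The estimate for compound 4 is 160000 nM, range 45000 nM to 500000 nM.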

Compound 4, half-maximal inhibitory concentration: 105000 nM
Compound 4: middle estimate off by 1.5-fold (0.18 log units), on the high side, within the range that was stated.
By their numbers in this assay, from the lowest: compounds 3 and 4 (each within the scatter of the next); then compound 1.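

In this assay the step of a 1.0-fold higher number from compound 3 to compound 4 (0.01 log units; within the scatter) shows that 4-hydroxyphenyl and furan-2-yl cannot be told apart at this place next to the ring nitrogen. Ring size alone therefore does not set the number: compound 1 also carries a six-membered aromatic ring of carbon only, and the step of a 2.6-fold lower number from compound 1 to compound 4 (0.41 log units; beyond the scatter) comes with hydroxy in place of chloro. No evidence on hand gives a cause for either step. From the compounds shown here alone, what an amine or a methoxy group in place of the hydroxy would give remains open. Going by these compounds, compound 2 has no number, so a saturated ring at this place also remains open.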